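The source may hold more compounds than are shown below. What is called first, only, known or untested is meant among the compounds shown, and "the series" means these compounds.

Compound 1 `COc1ccc(C(=O)/C=C/c2cccc(F)c2)c2c1C=CC(C)(C)O2` and compound 2 `COc1ccc(C(=O)/C=C/c2ccc(O)c(Br)c2)c2c1C=CC(C)(C)O2` share one core and differ only at the aryl group on the double-bonded chain carbon. In a functional assay on SW-620 cells (Homo sapiens) for antiproliferative activity, read by MTT assay, with a stated time of 24 h (on this read-out higher numbers stand for weaker inhibition and lower numbers for stronger inhibition), compound 1 gives only a limit, > 10000 nM. Compound 2 likewise reaches only a limit in this assay, namely > 10000 nM. The step that the two limits leave unreadable from compound 1 to compound 2 cannot be sized because of the limit of > 10000 nM in this assay, at which 2 of the 2 values shown sit. Compound 3 `COc1ccc(C(=O)/C=C/c2cc(Cl)ccc2O)c2c1C=CC(C)(C)O2` differs from compound 2 by 5-chloro-2-hydroxyphenyl in place of 3-bromo-4-hydroxyphenyl on a double-bonded chain carbon bound to a double-bonded chain carbon. No readable step bears on this change, since both earlier values sit at the limit. Compound 3 is therefore expected to stay weak, with an estimated step that the limit leaves unreadable from compound 2 to compound 3 and an expected value of 15000 nM, ranging from 4000 nM to 60000 nM.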

Compound 3, half-maximal inhibitory concentration: 4230 nM
For compound 3 the middle estimate is 3.5-fold (0.55 log units) above the measured one, within the range that was stated.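

In this assay, going by these compounds alone, the aryl group at this place now gives a readable number: compound 3 gives 4230 nM, the only value shown that is not a limit. Putting 5-chloro-2-hydroxyphenyl in place of 3-bromo-4-hydroxyphenyl gives an at least 2.3-fold lower number from compound 2 to compound 3 (0.37 log units; beyond the scatter), and putting it in place of 3-fluorophenyl gives an at least 2.3-fold lower number from compound 1 to compound 3 (0.37 log units; beyond the scatter). Both steps start from a limit, so their full size cannot be read: the limit of > 10000 nM in this assay, at which 2 of the 3 values shown sit.

The change from compound 2 to compound 3 swaps bromine for chlorine and alters the substitution pattern together, and the compounds shown do not separate the two. Also open, going by these compounds, is how an amine or a carboxylic acid in place of the chlorine would read.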